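Methyl Ester of a Weakly Active Cell Assay Compound

The source may report more compounds than this note shows. Statements on the series, on what has been measured and on what is new or still open speak of the compounds shown alone.

Measured so far:
Compound 1, `CC1(C)N(O)C(c2ccc(OCC(=O)NCCCC[C@H](N)C(=O)O)cc2)=[N+]([O-])C1(C)C`: 29900 nM
Compound 2, `CC1(C)N(O)C(c2ccc(OCCNC(=O)C[C@H](N)C(=O)O)cc2)=[N+]([O-])C1(C)C`: 48600 nM

Both compounds were tested in a functional assay on PC-12 cells (Rattus norvegicus) for inhibition, read by MTT assay; a lower number here means that less compound is needed, a higher number that more compound is needed for the effect. Compound 2 carries the higher of the two numbers, yet its gap to compound 1 lies within the scatter, so the two cannot be told apart on these data; both need a large amount of compound for the effect.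

Compound 3, `COC(=O)[C@@H](N)CC(=O)NCCOc1ccc(C2=[N+]([O-])C(C)(C)C(C)(C)N2O)cc1`, differs from compound 2 by methyl in place of hydrogen on an oxygen next to a carbonyl group. Going by the values given here, no pair of measured compounds shows this kind of change, so there is no measured step to lean on; the expectation rests only on compound 2 and the small size of the change. The step of a 1.4-fold lower number from compound 2 to compound 3 (0.14 log units; within the scatter) is expected to stay within the usual scatter, if anything towards a slightly lower number. Compound 3 is therefore expected to give 35000 nM, with a range from 12000 nM to 100000 nM.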

Compound 3, half-maximal effective concentration: 47800 nM
Estimate against measurement, compound 3: 1.4-fold (0.14 log units) below; the range from low to high includes it.
By their numbers in this assay, from the lowest: compounds 1, 3 and 2 (each within the scatter of the next).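

In this assay, methyl in place of hydrogen on an oxygen next to a carbonyl group, which turns carboxy into methoxycarbonyl, gives a 1.0-fold lower number from compound 2 to compound 3 (0.01 log units; within the scatter) and so leaves the number unchanged within the scatter. Going by these compounds alone, this is the first measured step at this position, and it shows that the hydrogen of the carboxy group in compound 2 is not needed to keep the number at this level, since compound 3 lacks it. No measurement bears on why this change makes so little difference.

On these data alone, whether a larger ester, such as ethoxycarbonyl, would also leave the number in place remains open. So does the effect of a primary amide in place of the carboxy group, which would show how far this position tolerates change.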